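Acetylated and free thiosugar amides on breast cancer cells

The compounds below may be only part of what the source reports. "The series", "measured", "known", "first", "only" and "open" are said of these compounds alone.

Compound 1 `CCCCCCCCCCCCCC(=O)Nc1nnc(S[C@@H]2O[C@H](COC(C)=O)[C@H](OC(C)=O)[C@H](OC(C)=O)[C@H]2OC(C)=O)s1` is a tetradecanamide carrying a fully acetylated thiosugar on its heteroaromatic core. In a functional assay on MDA-MB-231 cells (Homo sapiens) for cytotoxicity, read by MTT assay, with a stated time of 24 h (on this read-out lower numbers stand for stronger inhibition and higher numbers for weaker inhibition), compound 1 gives 26200 nM. Compound 2 `CCCCCCCC/C=C\CCCCCCCCCCCC(=O)Nc1nnc(S[C@@H]2O[C@H](COC(C)=O)[C@H](OC(C)=O)[C@H](OC(C)=O)[C@H]2OC(C)=O)s1` keeps that acetylated core and extends the chain by dec-1-en-1-yl in place of ethyl on a saturated chain carbon, ten or more bonds along the chain from a carbonyl carbon. In this assay compound 2 gives 25300 nM, so a 1.0-fold lower number from compound 1 to compound 2 (0.02 log units; within the scatter).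

Compound 3 `CCCCCCCCCCCCCC(=O)Nc1nnc(S[C@@H]2O[C@H](CO)[C@H](O)[C@H](O)[C@H]2O)s1` carries the same tetradecanamide as compound 1 on a core whose thiosugar hydroxyls are free; the difference between the two cores is not broken down here. In this assay compound 3 gives 33300 nM.

Compound 4 `CCCCCCCC/C=C\CCCCCCCCCCCC(=O)Nc1nnc(S[C@@H]2O[C@H](CO)[C@H](O)[C@H](O)[C@H]2O)s1` is the unmeasured partner of compound 3: it differs from compound 3 by dec-1-en-1-yl in place of ethyl on a saturated chain carbon, ten or more bonds along the chain from a carbonyl carbon, the same change that separates compound 1 from compound 2. Since that change left compound 1 and compound 2 within the scatter of each other, the step expected from compound 3 to compound 4 is a 1.0-fold lower number from compound 3 to compound 4 (0.02 log units; within the scatter), again within the scatter. On that basis compound 4 is estimated in this assay at 32000 nM, with a likely span from 20000 nM to 50000 nM.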

Compound 4, half-maximal inhibitory concentration: 70400 nM
For compound 4 the middle estimate is 2.2-fold (0.34 log units) below the measured one; measured number outside the range, above it.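

In this assay the change from ethyl to dec-1-en-1-yl brings a 2.1-fold higher number from compound 3 to compound 4 (0.33 log units; beyond the scatter) on the core with free hydroxyls, whereas on the acetylated core it brought a 1.0-fold lower number from compound 1 to compound 2 (0.02 log units; within the scatter). Set side by side, the two steps cannot be told apart with confidence: the same change on two cores in this assay, a 1.0-fold lower number (0.02 log units; within the scatter) from compound 1 to compound 2 and a 2.1-fold higher number (0.33 log units; beyond the scatter) from compound 3 to compound 4, 2.2-fold (0.34 log units) apart, within the scatter of two such steps. The two pairs therefore give no firm sign that the change behaves differently on the two cores, but with a single pair on each core they do not establish that it carries over unchanged, and they do not explain the step seen with compound 4.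

The compounds shown leave open how a saturated chain or a much shorter chain, such as an octanoyl group, would behave on either core, and whether a thiosugar with only some of its acetyl groups would follow either pair. They also leave open what an amine or a carboxylic acid at the far end of the chain would do.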